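Fluoro for methyl on the aryl group of compound 2

A few compounds are considered here, and "the series" means these few. Any claim that something is new, unique, unknown or untested is made for them only; others in the source may bear on it.

Measured so far:
compound 1, `CCCCN1C(=O)NC2(CC2(C)C)C1=O`: 90%
compound 2, `Cc1ccc(N2C(=O)NC3(CC3(C)C)C2=O)cc1`: 50%

In a functional assay on the whole organism for inhibition, with Mus musculus as the target, in the maximal electroshock model, at a dose of 30 mg/kg by the oral route (a lower number here means a weaker effect, a higher number a stronger effect of the compound at the dose given), compound 1 gives 90%. In this assay compound 2 gives 50%, the lowest of the two numbers; its nearest neighbour, compound 1, lies beyond the scatter above it. Among the measured compounds shown here, no step between two measured compounds that differ in a single place has been recorded, so the pair says only that the butyl-bearing core of compound 1 outperforms the aryl-bearing core of compound 2.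

Compound 3, `CC1(C)CC12NC(=O)N(c1ccc(F)cc1)C2=O`, is still to be measured in this assay. Compared with compound 2 the change is fluoro in place of methyl on an aromatic carbon. Nothing measured covers a swap of one substituent on this aryl group, so the step is expected to be small, with no clear direction and likely none beyond the scatter: a number 5 percentage points higher from compound 2 to compound 3 (within the scatter). Compound 3 is accordingly estimated at 55%, within 25% to 85%.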

Compound 3, a percentage reported as inhibition, in the whole organism at one dose (the size of the read-out at that dose, not a potency): 80%
The estimate for compound 3 lay 25 percentage points below the measured number, and the stated range covers the measured number.
By their numbers in this assay, from the lowest: compound 2; then compounds 3 and 1 (each within the scatter of the next).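

In this assay, the position on an aromatic carbon para to a large group proves sensitive: fluoro in place of methyl, a swap of one heavy atom with no change in hydrogen-bond donors or acceptors, gives a number 30 percentage points higher from compound 2 to compound 3 (beyond the scatter). The aryl group as such therefore does not fix the read-out near the level of compound 2, since compound 3 keeps that group and gives 80%; the earlier contrast between the butyl-bearing and aryl-bearing compounds has to be read with this in mind. No measurement at hand accounts for the step.

Open, going by these compounds, is whether chloro, methoxy, trifluoromethyl or plain hydrogen at this position would read like compound 3 or like compound 2. Also open, on these data alone, is whether the step would hold at other doses, as each number here reflects a single dose and is not a potency.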